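Aryl Ether in Place of Hexyl Ether on the Lactone Core

This account rests on a few compounds, and the source may have more. Where it says the series, first, only, none or still open, it means among the compounds named here.

Compound 1 `CCCCCCOc1ccc(C(O)C2OC(=O)c3c(OC)cc(OC)cc32)cc1` and compound 2 `COCCCCOc1ccc(C(O)C2OC(=O)c3c(OC)cc(OC)cc32)cc1` share a core and differ only in their chain. In a functional assay on RAW264.7 cells (Mus musculus) for inhibition, read by Griess assay, with stated times of 1 h and 24 h (on this read-out higher numbers stand for weaker inhibition and lower numbers for stronger inhibition), compound 1 gives 5360 nM, and compound 2 gives 8210 nM; the change a 1.5-fold higher number from compound 1 to compound 2 (0.19 log units; within the scatter) lies within the scatter. Compound 1 thus shows the lower of the two numbers, though not separated from compound 2 beyond the scatter. Compound 3 `COc1cc(OC)c2c(c1)C(C(O)c1ccc(OCc3ccc(Br)cc3)cc1)OC2=O` differs from compound 1 by 4-bromophenyl in place of pentyl on a saturated chain carbon bound to an oxygen on an aromatic ring. Within the data shown here, only the step from compound 1 to compound 2 offers a comparison, and it was small, yet it swaps a chain group rather than introducing a ring, so it bears weakly here. The step of a 1.1-fold lower number from compound 1 to compound 3 (0.03 log units; within the scatter) is therefore expected to stay near the scatter, with a wide range. Compound 3 is estimated at 5000 nM, between 1500 nM and 18000 nM.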

Compound 3, half-maximal inhibitory concentration: 6530 nM
For compound 3 the middle estimate is 1.3-fold (0.12 log units) below the measured one; measured number inside the range.
By their numbers in this assay, from the lowest: compounds 1, 3 and 2 (each within the scatter of the next).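

In this assay, among these compounds, a six-membered aromatic ring now stands at this position for the first time, and 4-bromophenyl in place of pentyl gives a 1.2-fold higher number from compound 1 to compound 3 (0.09 log units; within the scatter). Set against the 3-methoxypropyl chain, the same group gives a 1.3-fold lower number from compound 2 to compound 3 (0.10 log units; within the scatter), so on a saturated chain carbon bound to an oxygen on an aromatic ring, neither step leaves the scatter. No available evidence bears on this result. As far as these compounds go, what an unsubstituted phenyl, an amine, a carboxylic acid or a longer chain would give at this place stays open.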